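A few compounds are considered here, and "the series" means these few. Any claim that something is new, unique, unknown or untested is made for them only; others in the source may bear on it.

Measured compounds:
- compound 1, `O=C(OCCCCOc1ccccc1)c1cccc(=O)[nH]1`: in an assay on isolated protein for inhibition of matrix metalloproteinase-9 (Homo sapiens) (a higher number here means a weaker inhibitor, a lower number a stronger inhibitor), compound 1 gives 94000 nM
- compound 2, `CC(C)OC(=O)c1cccc(S)n1`: in this assay compound 2 gives 132000 nM

For the measured compounds named here, compound 2 is one of only two measured compounds, and its number in this assay lies within the usual scatter of the number for compound 1, so the two cannot be told apart on these data. Compound 3, `O=C(OC1CCC1)c1cccc(S)n1`, is not yet measured. It differs from compound 2 in one place: cyclobutyl in place of isopropyl on an oxygen next to a carbonyl group. Both groups carry no donor and no acceptor and no charge, and the change sits on the oxygen next to the carbonyl group. Going by the values given here, there is no measured pair that would show what such an exchange does in this assay. For compound 3 the expected step from compound 2 is therefore small, a 1.0-fold lower number from compound 2 to compound 3 (0.01 log units; within the scatter), and in no particular direction beyond the scatter. Compound 3 is thus estimated at 130000 nM in this assay, with a range from 50000 nM to 350000 nM.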

Compound 3, half-maximal inhibitory concentration: 137000 nM
Estimate against measurement, compound 3: 1.1-fold (0.02 log units) below, within the range that was stated.
By their numbers in this assay, from the lowest: compounds 1, 2 and 3 (each within the scatter of the next).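

In this assay, for the compounds shown here, the pair gives a 1.0-fold higher number from compound 2 to compound 3 (0.02 log units; within the scatter), the first measured exchange at this position, on the oxygen next to a carbonyl group. Replacing isopropyl with cyclobutyl adds a four-membered non-aromatic ring of carbon only and takes the group from 3 to 4 heavy atoms, yet this pair cannot be told apart, so this one change does not separate the two groups in this assay. No measurement at hand accounts for this result. The compounds shown leave open whether any group on this oxygen moves the number beyond the scatter, since both groups compared here are carbon only and uncharged. An amine, a carboxylic acid or a benzyl group at this place could answer that.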